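A few compounds are considered here, and "the series" means these few. Any claim that something is new, unique, unknown or untested is made for them only; others in the source may bear on it.

Among the compounds with values here, in a functional assay on HL-60 cells (Homo sapiens) for inhibition (on this read-out higher numbers stand for weaker inhibition of growth and lower numbers for stronger inhibition of growth), compound 1 (`C=C(C)C(=O)c1ccc(OCc2nc(C)no2)cc1C`) gives 3820 nM and compound 2 (`C=C(C)C(=O)c1ccc(OCc2nc(-c3ccc(C(F)(F)F)cc3)no2)cc1Br`) gives 1700 nM as the only two numbers so far. Compound 1 therefore holds the higher number, which marks it as the weaker growth inhibitor of this pair, by a gap beyond the usual scatter. Compound 3 (`C=C(C)C(=O)c1ccc(OCc2nc(-c3ccccc3)no2)cc1C`) has not yet been measured and differs from compound 1 in one place: phenyl in place of methyl on an aromatic carbon. Within the data shown here, no measured pair shows this change alone. Compound 2 gives 1700 nM with a six-membered aromatic ring at that place, but it also differs from compound 1 elsewhere, so it is only a weak guide. The estimated step (a 2.1-fold lower number from compound 1 to compound 3 (0.33 log units; beyond the scatter)) is expected to be modest and toward stronger inhibition of growth in this assay for now. Compound 3 is expected at 1800 nM with a likely range from 600 nM to 4500 nM in this read-out.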

Compound 3, concentration for 50% growth inhibition: 6700 nM
The estimate for compound 3 lay 3.7-fold (0.57 log units) below the measured number, and the stated range ends below it.
By their numbers in this assay, from the lowest: compound 2; then compounds 1 and 3 (each within the scatter of the next).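

Within the data shown here, this pair is the first to differ in this one place alone, so it gives the first direct reading of the position. In this assay, putting phenyl in place of methyl on the aromatic carbon of the five-membered ring gives a 1.8-fold higher number from compound 1 to compound 3 (0.24 log units; within the scatter), so the two compounds cannot be told apart on this read-out. This place on the ring therefore carries either methyl or a whole phenyl ring without a separable difference in growth inhibition, and no supporting measurement offers a reason for this.

From the compounds shown here alone, whether a different kind of group at this place, such as an amine, a carboxylic acid or a longer carbon chain, would separate from methyl and phenyl remains open. Going by these compounds, whether this reading holds when the rest of the core of compound 1 carries other groups also remains open.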